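Chain unsaturation on two arrangements of a dithioacetal core

This account rests on a few compounds, and the source may have more. Where it says the series, first, only, none or still open, it means among the compounds named here.

The study compares two cores. Compound 1 `CCCCCCCCCOc1ccccc1C(SCCC(=O)O)SCCC(=O)O` and compound 3 `CCCCCCCCCOc1cccc(C(SCCC(=O)O)SCCC(=O)O)c1` are built from the same atoms joined differently; the difference between the two cores is not broken down here. In an assay on membranes from lung (Cavia porcellus) for binding affinity to cysteinyl leukotriene receptor (Homo sapiens) (a lower number here means a stronger inhibitor, a higher number a weaker inhibitor), compound 1 gives 4090 nM, and compound 3 gives 624 nM. Compound 2 `CCCCC/C=C/C/C=C/COc1ccccc1C(SCCC(=O)O)SCCC(=O)O` carries deca-1,4-dien-1-yl in place of octyl on a saturated chain carbon bound to an oxygen on an aromatic ring, and in this assay compound 2 gives 1000 nM, a step of a 4.1-fold lower number from compound 1 to compound 2 (0.61 log units; beyond the scatter). Compound 4 `CCCCC/C=C/C/C=C/COc1cccc(C(SCCC(=O)O)SCCC(=O)O)c1` applies the same change to compound 3, namely (deca-1,4-dien-1-yl in place of octyl on a saturated chain carbon bound to an oxygen on an aromatic ring), at a place described in the same words. Within the data shown here, since compound 3 sits at 624 nM, the step from compound 3 to compound 4 is expected to be a 3.1-fold lower number from compound 3 to compound 4 (0.49 log units; beyond the scatter), a little smaller than the earlier one because the step of a 4.1-fold lower number from compound 1 to compound 2 (0.61 log units; beyond the scatter) is the only guide available. Compound 4 is therefore estimated at 200 nM in this assay, between 70 nM and 600 nM.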

Compound 4, inhibition constant: 187 nM
For compound 4 the middle estimate is 1.1-fold (0.03 log units) above the measured one; the measured number falls inside the stated range.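

In this assay, deca-1,4-dien-1-yl in place of octyl gives a 3.3-fold lower number from compound 3 to compound 4 (0.52 log units; beyond the scatter), and this step agrees with the earlier one on the other core: the same change on two cores in this assay, a 4.1-fold lower number (0.61 log units; beyond the scatter) from compound 1 to compound 2 and a 3.3-fold lower number (0.52 log units; beyond the scatter) from compound 3 to compound 4, 1.2-fold (0.09 log units) apart, within the scatter of two such steps. Across these two cores, then, the change carries over with a similar size. This does not show that it would hold on any other core, and with a single pair on each core it cannot separate the longer chain from its double bonds.

The compounds shown leave open whether a saturated decyl chain on either core would give the same step. They also leave open how a longer chain, or a carboxylic acid at the end of the chain, would fare.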